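The source may hold more compounds than are shown below. What is called first, only, known or untested is meant among the compounds shown, and "the series" means these compounds.

Compound 2 `COc1cc(-c2cc(/C=C/C(=O)c3ccc(Cl)c(Cl)c3)[nH]n2)cc(OC)c1OC`: 12%
Compound 1 `COc1ccc(-c2cc(/C=C/C(=O)c3ccc(N)cc3)[nH]n2)cc1`: -80%

The measure here is a functional assay on SNB-19 cells (Homo sapiens) for cytotoxicity, read by sulforhodamine B assay, with a stated time of 48 h, tested at 100 uM; a lower number here means a stronger effect, a higher number a weaker effect of the compound at the concentration tested. Among the two numbers shown, compound 2 has the highest, meaning the weaker effect at the concentration tested. Its nearest neighbour is compound 1, and in this assay compound 1 gives -80%, a number far below that of compound 2, well beyond the usual scatter of repeated measurements.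

Compound 3 `COc1ccc(C(=O)/C=C/c2cc(-c3cc(OC)c(OC)c(OC)c3)n[nH]2)cc1` has not yet been measured. Its structure differs from compound 2 in one place: 4-methoxyphenyl in place of 3,4-dichlorophenyl on a carbonyl carbon. Among the measured compounds shown here, no pair of measured compounds shares exactly this change, so there is no measured step to lean on. Compound 1 does show that the shared core can reach a strongly negative reading, but compound 1 differs from compound 3 in more than one place, so it guides only loosely. The expected step in this assay is a number 32 percentage points lower from compound 2 to compound 3 (beyond the scatter), a move downward toward a stronger effect that carries wide uncertainty. Compound 3 is therefore estimated at -20%, within a range from -70% to 25%.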

Compound 3, a percentage reported as activity, at one concentration (the size of the read-out at that concentration, not a potency): -6%
Beside the measured number, compound 3's estimate is 14 percentage points below it; low and high end bracket the measured number.
By their numbers in this assay, from the lowest: compound 1; then compound 3; then compound 2.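

In this assay, among the compounds shown here, putting 4-methoxyphenyl in place of 3,4-dichlorophenyl on the carbonyl carbon gives a number 18 percentage points lower from compound 2 to compound 3 (beyond the scatter), the first direct evidence that the group at this position alters the read-out while the rest of the molecule stays fixed. The two groups have the same heavy-atom count and each holds one six-membered aromatic ring of carbon only, so the step comes with a swap of two chlorine atoms for a methoxy group, which adds one hydrogen-bond acceptor, and not with a change in the count of heavy atoms. Nothing measured here explains why this swap shifts the read-out, so the step stands as an observation without a cause.

A single step between two groups gives no trend, and compound 1 differs from compound 3 in more than one place, so it cannot show how far this position alone can move the read-out. As far as these compounds go, it also remains open how a carboxylic acid or a single fluorine on this phenyl ring would behave with the rest of compound 3 unchanged.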